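Moving from 4-Nitrobenzyl to 2-(Trifluoromethyl)benzyl

This account rests on a few compounds, and the source may have more. Where it says the series, first, only, none or still open, it means among the compounds named here.

compound 1 `COc1cc(OC)c(-c2coc3cc(OCc4ccc(F)cc4)ccc3c2=O)cc1OC` - 3200 nM
compound 2 `COc1cc(OC)c(-c2coc3cc(OCc4ccc([N+](=O)[O-])cc4)ccc3c2=O)cc1OC` - 9400 nM
compound 3 `COc1cc(OC)c(-c2coc3cc(OCc4ccccc4C(F)(F)F)ccc3c2=O)cc1OC` - not yet measured

In a functional assay on U-251 cells (Homo sapiens) for antiproliferative activity, read by MTT assay, with a stated time of 24 h (on this read-out lower numbers stand for stronger inhibition and higher numbers for weaker inhibition), compound 2 stands at 9400 nM as the higher of the two numbers, making it the weaker inhibitor of the pair. Going on to compound 3 brings 2-(trifluoromethyl)phenyl in place of 4-nitrophenyl on a saturated chain carbon bound to an oxygen on an aromatic ring in one place: 2-(trifluoromethyl)phenyl in place of 4-nitrophenyl on a saturated chain carbon bound to an oxygen on an aromatic ring. Going by the values given here, one measured step bears on this, a 2.9-fold higher number from compound 1 to compound 2 (0.47 log units; beyond the scatter) and it is modest but beyond the scatter. Nitro leaves again here, though fluoro does not return, so a partial recovery is expected, estimated as a 1.9-fold lower number from compound 2 to compound 3 (0.27 log units; within the scatter) in all. In this assay compound 3 is estimated at 5000 nM with 2000 nM and 12000 nM as the ends of the expected range.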

Compound 3, half-maximal inhibitory concentration: > 10000 nM
Compound 3 gave a limit, no number; the forecaster's own chance of this, stated with the estimate: 5%; middle value at least 2.0-fold (0.30 log units) away from the limit.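

Compound 3 gives only a limit in this assay, not a number: the limit of > 10000 nM in this assay, at which 1 of the 3 values shown sits. Replacing 4-fluorophenyl with 2-(trifluoromethyl)phenyl gives an at least 3.1-fold higher number from compound 1 to compound 3 (0.49 log units; beyond the scatter), so at this position the loss of nitro alone does not bring back the number of compound 1, which now has the lowest number of the three. The other step, an at least 1.0-fold higher number from compound 2 to compound 3 (0.02 log units; that floor lies within the scatter), is only a floor, so no order can be set between those two compounds.

The compounds shown leave open whether compound 2 and compound 3 truly differ. They also leave open how an unsubstituted phenyl or an amine-bearing phenyl would read at this position.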